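Benzyl in place of ethyl esters and cell toxicity

The source may hold more compounds than are shown below. What is called first, only, known or untested is meant among the compounds shown, and "the series" means these compounds.

Compound 1, `C=C[C@@](C)(/C=C/c1ccc(O)cc1)CC/C=C(C)/C=C/C(=O)OCC`, gives a limit of the assay: > 36600 nM.
Compound 2, `C=C[C@@](C)(/C=C/c1ccc(O)cc1)CC/C=C(C)/C=C/C(=O)OCc1ccccc1`, gives a limit of the assay: > 36600 nM.
Compound 3, `C=C[C@@](C)(/C=C/c1ccc(O)c(/C=C/C(=O)OCC)c1)CCC=C(C)C`, gives a limit of the assay: > 36600 nM.

In an ADME assay on BJ cells (Homo sapiens) for cytotoxicity, with a stated time of 72 h (on this read-out lower numbers stand for an effect already at smaller amounts and higher numbers for an effect only at larger amounts of compound), compound 1 reaches only a limit, > 36600 nM. Compound 2 likewise shows only a limit, > 36600 nM. Compound 3 too shows only a limit, > 36600 nM. The change from compound 1 to compound 2 is phenyl in place of methyl on a saturated chain carbon bound to an oxygen next to a carbonyl group, and its step, a step that the two limits leave unreadable from compound 1 to compound 2, stays unreadable because of the limit of > 36600 nM in this assay, at which 3 of the 3 values shown sit. Compound 4, `C=C[C@@](C)(/C=C/c1ccc(O)c(/C=C/C(=O)OCc2ccccc2)c1)CCC=C(C)C`, has not yet been measured; it differs from compound 3 by phenyl in place of methyl on a saturated chain carbon bound to an oxygen next to a carbonyl group, the same change as before. How the core of compound 1 differs from the core of compound 3 is not broken down here. Since the same change left compound 2 at a limit, compound 4 is expected to sit near a limit as well, an estimated step that the limit leaves unreadable from compound 3 to compound 4. The expected value for compound 4 is 40000 nM, likely reported only as a limit.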

Compound 4, half-maximal effective concentration: > 36600 nM
Compound 4 gave a limit, no number (the forecaster's own chance of this, stated with the estimate: 85%); the middle value lies beyond the limit too.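

No step can be read from compound 3 to compound 4, because both results are limits, not numbers: the limit of > 36600 nM in this assay, at which 4 of the 4 values shown sit.

Whether ethyl to benzyl makes any difference in this assay stays open: none of the compounds shown gives an actual number.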